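Swapping methyls for chlorines on the aryl piperazine of compound 1

A few compounds are considered here, and "the series" means these few. Any claim that something is new, unique, unknown or untested is made for them only; others in the source may bear on it.

Compound 1 `Cc1cccc(N2CCN(CCCNc3nc(NCc4ccco4)c4ccccc4n3)CC2)c1C` was tested in a functional assay on A375P cells (Homo sapiens) for cytotoxicity, read by MTT assay, with a stated time of 2 days (on this read-out lower numbers stand for stronger inhibition and higher numbers for weaker inhibition), where compound 1 gives 3040 nM. Among the three measured compounds this number stands second highest: compound 3 `Cc1cccc(N2CCN(CCCNc3nc(NCc4ccco4)c4cc(F)ccc4n3)CC2)c1C` gives 2830 nM, and the step of a 1.1-fold lower number from compound 1 to compound 3 (0.03 log units; within the scatter) is too small to count as a real difference, while compound 2 `CCCCCNc1nc(NCc2ccco2)c2cc(F)ccc2n1` gives 7340 nM, a number beyond the scatter from compound 1 on the higher side.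

Compound 4 `Clc1cccc(N2CCN(CCCNc3nc(NCc4ccco4)c4ccccc4n3)CC2)c1Cl` differs from compound 1 in one place: 2,3-dichlorophenyl in place of 2,3-dimethylphenyl on an amine nitrogen in a ring. Going by the values given here, no measured step touches this part of the molecule. Among the compounds with values here, the only single-point step available, from compound 1 to compound 3, concerns a fluoro in place of hydrogen on an aromatic carbon elsewhere in the shared core and stays within the scatter, so it offers no guide to what a change on the aryl piperazine does. With nothing to point either way, the expectation for compound 4 is a step within the scatter, a 1.0-fold lower number from compound 1 to compound 4 (0.01 log units; within the scatter), so compound 4 is expected to give about 3000 nM in this assay, within a range from 1200 nM to 7500 nM.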

Compound 4, half-maximal inhibitory concentration: 3360 nM
Compound 4: middle estimate off by 1.1-fold (0.05 log units), on the low side; the range from low to high includes it.
By their numbers in this assay, from the lowest: compounds 3, 1 and 4 (each within the scatter of the next); then compound 2.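

Going by these compounds alone, this is the first measured change on the aryl group carried by the ring amine nitrogen, and in this assay putting 2,3-dichlorophenyl in place of 2,3-dimethylphenyl gives a 1.1-fold higher number from compound 1 to compound 4 (0.04 log units; within the scatter) and so leaves no real difference. Two chlorines can therefore stand where the two methyls stood, on an aryl group of the same heavy-atom count, without a change that this cytotoxicity read-out can detect. Nothing available explains why the two groups read alike.

As far as these compounds go, whether a plain phenyl or a phenyl carrying methoxy or nitrile would read the same at this place remains open. From the compounds shown here alone, it is also open whether 2,3-dichlorophenyl would read alike on the fluoro-bearing core of compound 3.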